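Cytotoxicity at the Limit: Cyclopropyl Gives Way to Propyl

The source may report more compounds than this note shows. Statements on the series, on what has been measured and on what is new or still open speak of the compounds shown alone.

Compound 1, `O=C(c1ccccc1F)N1CCN(c2nc(=O)c3cc(C(F)(F)F)cc([N+](=O)[O-])c3s2)CC1`, gives > 125000 nM in an ADME assay on Vero cells (Chlorocebus sabaeus) for cytotoxicity, read by MTT assay, with a stated time of 72 h (on this read-out higher numbers stand for lower toxicity in this test and lower numbers for higher toxicity in this test), a limit of the measurement.
Compound 2, `CC1COC2(CCN(c3nc(=O)c4cc(C(F)(F)F)cc([N+](=O)[O-])c4s3)CC2)O1`, gives > 125000 nM in this assay, again a limit.
Compound 3, `O=C(C1CC1)N1CCN(c2nc(=O)c3cc(C(F)(F)F)cc([N+](=O)[O-])c3s2)CC1`, gives > 125000 nM in this assay, also a limit.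

Compound 3 thus stands where the other two stand: at the limit, with no number of its own. Going by the values given here, the one measured change leading to it, a step that the two limits leave unreadable from compound 1 to compound 3, cannot be read as a step, since both ends are limits. The next compound, compound 4, `CCCC(=O)N1CCN(c2nc(=O)c3cc(C(F)(F)F)cc([N+](=O)[O-])c3s2)CC1`, differs from compound 3 by propyl in place of cyclopropyl on a carbonyl carbon. Among the compounds with values here, no measured step bears on this change with a readable size; what is known is the limit of > 125000 nM in this assay, at which 3 of the 3 values shown sit, which places every value so far at the same limit. Within the data shown here, for compound 4 the expectation is accordingly that the value once more sits at the limit, with no step in this assay beyond the scatter. The step that this estimate means is a number no higher from compound 3 to compound 4 (the limit leaves the size open). Compound 4 is estimated at 125000 nM, between 60000 nM and 250000 nM, and is most likely to be reported as a limit again.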

Compound 4, half-maximal cytotoxic concentration: > 125000 nM
Compound 4: a limit, no number; the forecaster's own chance of this, stated with the estimate: 85%; the middle value lies on the limit itself.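

Compound 1, compound 3 and compound 4 all sit at a limit in this assay, so no step among them can be read: the limit of > 125000 nM in this assay, at which 4 of the 4 values shown sit.

The compounds shown leave open whether propyl, cyclopropyl or 2-fluorophenyl on the carbonyl carbon makes any difference to the read-out.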